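Swapping Nitro for Chloro Ahead of a Cell Inhibition Test

The source may hold more compounds than are shown below. What is called first, only, known or untested is meant among the compounds shown, and "the series" means these compounds.

Measured compounds:
compound 1 `COc1cc(OC)c(-c2cc(=O)c3ccc(O)cc3o2)cc1OC`, a limit: > 150000 nM
compound 2 `COc1cc(OC)c(OC)cc1/C=C/C(=O)c1ccc([N+](=O)[O-])cc1`, a limit: > 150000 nM

In a functional assay on HeLa cells (Homo sapiens) for inhibition, read by MTT assay, with a stated time of 72 h (a higher number here means a weaker inhibitor, a lower number a stronger inhibitor), compound 1 reaches only a limit of the assay, > 150000 nM, so no number is known for it. Compound 2 likewise gives only a limit, > 150000 nM. Compound 2 therefore stands where every value here stands: the limit of > 150000 nM in this assay, at which 2 of the 2 values shown sit. Compound 3 `COc1cc(OC)c(OC)cc1/C=C/C(=O)c1ccc(Cl)cc1` has not yet been measured. It differs from compound 2 in one place: chloro in place of nitro on an aromatic carbon. For the measured compounds named here, no measured pair of compounds shows what this change does, so the size of the step is open. With both measured values sitting at the limit, the step of a number no higher from compound 2 to compound 3 (the limit leaves the size open) is expected to be no larger than the usual scatter, in no clear direction. Compound 3 is accordingly estimated at 150000 nM, within 40000 nM to 500000 nM, and most likely again reported only as a limit.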

Compound 3, half-maximal inhibitory concentration: 36500 nM
The estimate for compound 3 lay 4.1-fold (0.61 log units) above the measured number, outside the stated range (below it).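

Putting chloro in place of nitro on this aromatic carbon, para to a large group, gives an at least 4.1-fold lower number from compound 2 to compound 3 (0.61 log units; beyond the scatter) in this assay. The earlier compounds shown here showed only limits. Compound 3, at 36500 nM, gives a real number, so the group at this position can bring the shared core within the range of the assay. The step has only a lower bound, and its full size stays unknown, because compound 2 is itself a limit and not a number: the limit of > 150000 nM in this assay, at which 2 of the 3 values shown sit.

A single pair cannot tell whether the difference comes from chloro entering or nitro leaving. As far as these compounds go, how an amine, a fluoro group or a plain hydrogen at this position would read remains open, as does whether the same swap would matter on a different core.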